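Methoxy scan around a phenyl on a shared core

The source may report more compounds than this note shows. Statements on the series, on what has been measured and on what is new or still open speak of the compounds shown alone.

Measured compounds in an assay for displacement of a labelled ligand from Nicotinic acetylcholine receptor alpha8 subunit (Periplaneta americana), read by scintillation counting, with a stated time of 2 h, at 24 degrees C, tested at 10 uM; on this read-out higher numbers stand for more inhibition at the one concentration tested (going by the name of the read-out) and lower numbers for less inhibition:
- compound 1, `C(=C1\CCN=C1c1cccnc1)\c1ccccc1`: 41.3%
- compound 2, `COc1ccc(/C=C2\CCN=C2c2cccnc2)cc1`: 31.4%
- compound 3, `COc1cccc(/C=C2\CCN=C2c2cccnc2)c1`: 23.6%

Compound 1 gives the highest of the three numbers in this assay. Its nearest neighbour is compound 2, reached by the step of a number 9.9 percentage points lower from compound 1 to compound 2 (within the scatter), which stays within the scatter, so no order between the two can be claimed. The furthest is compound 3, reached by the step of a number 17.7 percentage points lower from compound 1 to compound 3 (beyond the scatter), a modest loss that does lie beyond the scatter. Both steps introduce a methoxy in place of hydrogen on an aromatic carbon of the same ring of the shared core, differing only in where that carbon sits.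

Compound 4, `COc1ccccc1/C=C1\CCN=C1c1cccnc1`, is not yet measured. It differs from compound 1 by methoxy in place of hydrogen on an aromatic carbon. The two measured steps of the same kind bear on it directly: one stayed within the scatter, the other was a modest loss. A small loss, or no change beyond the scatter, is therefore expected for compound 4, which amounts to the expected step of a number 11.3 percentage points lower from compound 1 to compound 4 (beyond the scatter). Compound 4 is estimated at 30%, in the range 15% to 45%.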

Compound 4, a percentage reported as inhibition, at one concentration (the size of the read-out at that concentration, not a potency): 49.5%
For compound 4 the middle estimate is 19.5 percentage points below the measured one, and the stated range ends below it.
By their numbers in this assay, from the lowest: compounds 3, 2, 1 and 4 (each within the scatter of the next, the first and the last beyond it).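

In this assay, methoxy in place of hydrogen on an aromatic carbon, ortho to a large group, gives a number 8.2 percentage points higher from compound 1 to compound 4 (within the scatter) and so brings no loss that can be claimed at this position. Among the compounds shown here, the same change had so far given only a result within the scatter or a modest loss, as in a number 17.7 percentage points lower from compound 1 to compound 3 (beyond the scatter), so compounds 1, 2 and 3 alone could not show that the outcome depends this clearly on where the methoxy sits, with compound 3 at 23.6% and compound 4 at 49.5% standing beyond the scatter of each other. Nothing measured here accounts for this difference between positions.

The compounds shown leave open whether a number level with that of compound 1 is specific to methoxy or would also be seen with another group on the same carbon, such as a hydroxyl, a fluorine or a longer ethoxy chain. They also leave open whether an amine or a carboxylic acid at this position would keep the read-out in the same range, and how any of these single-concentration percentages relate to potency.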